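Replacing the Amide of Compound 3 with Methoxymethyl

The source may hold more compounds than are shown below. What is called first, only, known or untested is meant among the compounds shown, and "the series" means these compounds.

Compound 1 `CCCOC(=O)c1c(C)coc1-c1ccc2c(CC)cccc2c1OC`: > 10 ug/mL
Compound 2 `CCc1cccc2c(OC)c(-c3occ(C)c3C(=S)OC)ccc12`: 5.8 ug/mL
Compound 3 `CCc1cccc2c(OC)c(-c3occ(C)c3C(=O)NC)ccc12`: > 10 ug/mL

In a functional assay on ZR-75-1 cells (Homo sapiens) for cytotoxicity, read by MTT assay, with a stated time of 72 h (on this read-out higher numbers stand for an effect only at larger amounts of compound and lower numbers for an effect already at smaller amounts), compound 3 gives > 10 ug/mL, which is a limit of the assay and not a number. Compound 1 also gives a limit in this assay, so that the limit of > 10 ug/mL in this assay, at which 2 of the 3 values shown sit, holds for two of the three values. Compound 2 gives 5.8 ug/mL in this assay. The two measured steps at this position of the shared core, an at least 1.7-fold lower number from compound 1 to compound 2 (0.23 log units; that floor lies within the scatter) and an at least 1.7-fold higher number from compound 2 to compound 3 (0.23 log units; that floor lies within the scatter), each only reach the floor set by a limit, and a step that the two limits leave unreadable from compound 1 to compound 3 is unreadable because both ends sit at the limit. Compound 4 `CCc1cccc2c(OC)c(-c3occ(C)c3COC)ccc12` differs from compound 3 by methoxymethyl in place of methylcarbamoyl on an aromatic carbon. For the measured compounds named here, no measured step shows this exact change, and the changes at this position so far have moved the number little. Compound 4 is therefore expected to sit near the limit again, at an estimated 12 ug/mL with a range from 4 ug/mL to 40 ug/mL. The expected step that the limit leaves unreadable from compound 3 to compound 4 is estimated to lie within the scatter.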

Compound 4, concentration for half-maximal effect: 9.7 ug/mL
Compound 4: middle estimate off by 1.2-fold (0.09 log units), on the high side; measured number inside the range.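

In this assay, for the compounds shown here, compound 4, with methoxymethyl in place of methylcarbamoyl, gives a number rather than a limit, which among the earlier compounds only compound 2 did. There is a 1.7-fold higher number from compound 2 to compound 4 (0.22 log units; within the scatter), so a sulfur-bearing group is not needed for a readable number at this position. The other two steps, an at least 1.0-fold lower number from compound 3 to compound 4 (0.01 log units; that floor lies within the scatter) and an at least 1.0-fold lower number from compound 1 to compound 4 (0.01 log units; that floor lies within the scatter), are only floors set by the limits of the assay for compound 1 and compound 3, so the real distance to compound 4 cannot be read: the limit of > 10 ug/mL in this assay, at which 2 of the 4 values shown sit.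

The compounds shown leave open whether the oxygen of methoxymethyl matters for the number in compound 4. They also leave open whether an amine, a carboxylic acid or a longer chain such as ethoxymethyl on this aromatic carbon would move the number beyond the scatter.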